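A few compounds are considered here, and "the series" means these few. Any claim that something is new, unique, unknown or untested is made for them only; others in the source may bear on it.

In a functional assay on RAW264.7 cells (Mus musculus) for inhibition, read by ELISA, with a stated time of 24 h (on this read-out higher numbers stand for an effect only at larger amounts of compound and lower numbers for an effect already at smaller amounts), compound 1 `CC/C=C\C[C@H]1C(=O)C=C[C@H]1CC(=O)OCC` gives 20000 nM. Compound 2 `CC/C=C\C[C@H]1C(=O)C=C[C@H]1CC(=O)Oc1ccc(O)cc1` gives 23000 nM and compound 3 `CC/C=C\C[C@H]1C(=O)C=C[C@H]1CC(=O)OCCO` gives 24000 nM, so compound 1 stands among three numbers that cannot be told apart: the steps are a 1.2-fold higher number from compound 1 to compound 2 (0.06 log units; within the scatter) and a 1.2-fold higher number from compound 1 to compound 3 (0.08 log units; within the scatter), and between the other two a 1.0-fold higher number from compound 2 to compound 3 (0.02 log units; within the scatter). Compound 4 `CC/C=C\C[C@H]1C(=O)C=C[C@H]1CC(=O)OC1CCCCC1` differs from compound 1 by cyclohexyl in place of ethyl on an oxygen next to a carbonyl group. Among the measured compounds shown here, the steps that bear on this change are the two at the same oxygen, a 1.2-fold higher number from compound 1 to compound 2 (0.06 log units; within the scatter) and a 1.0-fold higher number from compound 2 to compound 3 (0.02 log units; within the scatter), both within the scatter, so no step beyond the scatter is expected in this assay. Compound 4 is therefore estimated at 20000 nM, with a range from 8000 nM to 50000 nM. That estimate means an expected no change at the digits printed from compound 1 to compound 4 (within the scatter).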

Compound 4, half-maximal effective concentration: 22000 nM
Compound 4: the middle estimate sits 1.1-fold (0.04 log units) below what was measured; measured number inside the range.
By their numbers in this assay, from the lowest: compounds 1, 4, 2 and 3 (each within the scatter of the next).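

In this assay, the oxygen next to a carbonyl group now carries cyclohexyl, a six-membered non-aromatic ring of carbon only, and the numbers stay together: a 1.1-fold higher number from compound 1 to compound 4 (0.04 log units; within the scatter), a 1.1-fold lower number from compound 3 to compound 4 (0.04 log units; within the scatter) and a 1.0-fold lower number from compound 2 to compound 4 (0.02 log units; within the scatter), all within the scatter. Across the four compounds shown, this place has taken ethyl, 2-hydroxyethyl, 4-hydroxyphenyl and cyclohexyl with no step beyond the scatter. Nothing at hand explains this flat result.

On these data alone, it remains open whether an amine or a carboxylic acid at this oxygen would give a step beyond the scatter. Changes elsewhere on the core of compound 1 also remain untested here.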